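This account rests on a few compounds, and the source may have more. Where it says the series, first, only, none or still open, it means among the compounds named here.

Measured so far:
compound 1, `O=C(CCN(Cc1ccc(C(=O)NO)cc1)C(=O)c1ccccc1)NCc1ccccc1`, 12.5 nM
compound 2, `Cc1ccc(NC(=O)CCN(Cc2ccc(C(=O)NO)cc2)C(=O)c2ccccc2)cc1`, 10.7 nM

In an assay on Sf9 cells for inhibition of protein deacetylase HDAC6 (Homo sapiens), read by fluorescence, with stated times of 90 min and 30 min (on this read-out higher numbers stand for weaker inhibition and lower numbers for stronger inhibition), compound 1 gives the highest of the two numbers; the nearest is compound 2, and a 1.2-fold lower number from compound 1 to compound 2 (0.07 log units; within the scatter). Compound 3, `COc1ccc(C(=O)N(CCC(=O)NCc2ccccc2)Cc2ccc(C(=O)NO)cc2)cc1`, differs from compound 1 by methoxy in place of hydrogen on an aromatic carbon, on an aromatic carbon of a six-membered aromatic ring of carbon only, the benzoyl becoming (4-methoxyphenyl)carbonyl. Among the measured compounds shown here, no measured step touches this ring; the only step known, from compound 1 to compound 2, changes the amide nitrogen substituent and stays within the scatter. For compound 3 no step beyond the scatter is therefore expected in this assay, a 1.0-fold lower number from compound 1 to compound 3 (0.02 log units; within the scatter). The estimate for compound 3 is 12 nM, between 5 nM and 30 nM.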

Compound 3, half-maximal inhibitory concentration: 25.3 nM
The estimate for compound 3 lay 2.1-fold (0.32 log units) below the measured number; low and high end bracket the measured number.
By their numbers in this assay, from the lowest: compounds 2 and 1 (each within the scatter of the next); then compound 3.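

Among the compounds shown here, the benzoyl of compound 1 is the first place where a single change moves the number beyond the scatter: in this assay, methoxy para to a large group gives a 2.0-fold higher number from compound 1 to compound 3 (0.31 log units; beyond the scatter). The step is modest and rests on this one pair, so it shows that this position responds to methoxy but establishes no trend. Nothing available explains the higher number.

Open, from the compounds shown here alone, is whether fluoro, an amine or a carboxylic acid on the same carbon would shift the number in the same direction. Also open, going by these compounds, is whether methoxy on the benzoyl of compound 2 would give a similar step.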